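The compounds below may be only part of what the source reports. "The series", "measured", "known", "first", "only" and "open" are said of these compounds alone.

Of the compounds shown here, three have so far been measured in an ADME assay on A549 cells (Homo sapiens) for cytotoxicity, read by MTT assay, tested at 10 uM; a lower number here means a stronger effect, a higher number a weaker effect of the compound at the concentration tested. Compound 1 `O=S(=O)(c1c(F)c(F)c(F)c(F)c1F)N1CCN(c2ccccc2)CC1` gives 77%. Compound 2 `COc1ccc(C2CNC(=O)NC2)cc1O[C@@H]1C[C@H]2CC[C@H]1C2` gives 94.3%, and compound 3 `C=CCSc1nsc(NC(=O)Nc2ccc(Cl)cc2C(F)(F)F)n1` gives 95.8%. Among these three numbers compound 3 stands highest: its nearest neighbour is compound 2, whose number lies lower by an amount within the usual scatter, so no order can be claimed between the two, while the furthest is compound 1, whose number lies lower by an amount beyond the scatter.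

Compound 4 `C=CCSc1nsc(NC(=O)Nc2ccc(Cl)cc2)n1` has not yet been measured. It differs from compound 3 in one place, (hydrogen in place of trifluoromethyl on an aromatic carbon). Among the measured compounds shown here, no step between two measured compounds that differ in a single place is available, so the size of such a change cannot be read from any measured pair. Given that compound 3 already sits near the top of the scale at 95.8%, the step in this assay is expected to be a number 3.8 percentage points lower from compound 3 to compound 4 (within the scatter), not beyond the scatter. Compound 4 is accordingly estimated at 92%, with a range from 80% to 100%.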

Compound 4, a percentage reported as activity, at one concentration (the size of the read-out at that concentration, not a potency): 51.2%
Estimate against measurement, compound 4: 40.8 percentage points above; measured number outside the range, below it.
By their numbers in this assay, from the lowest: compound 4; then compound 1; then compounds 2 and 3 (each within the scatter of the next).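

In this assay, among the compounds shown here, the exchange of trifluoromethyl for hydrogen on the aromatic carbon meta to the chloro group gives a number 44.6 percentage points lower from compound 3 to compound 4 (beyond the scatter), the first step in this set between two compounds differing in one place. It shows that this position is far from indifferent to what it carries: the core shared by the two compounds, which gave little sign of an effect with trifluoromethyl, gives a much stronger effect with hydrogen. Nothing available accounts for the size of this step.

From the compounds shown here alone, whether a methyl or a methoxy group at this position would give a number nearer that of compound 3 or that of compound 4 remains open. Going by these compounds, it is also open whether a step of this size would hold with a nitrile in place of the chloro group.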